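This account rests on a few compounds, and the source may have more. Where it says the series, first, only, none or still open, it means among the compounds named here.

Measured so far:
compound 1 `CN(C)/C=N/c1c(C=O)c(-c2ccc(Cl)cc2)nn1-c1ccccc1`: 8100 nM
compound 2 `CCN(/C=N/c1c(C=O)c(-c2ccccc2)nn1-c1ccccc1)CC`: 30500 nM

In a functional assay on NPC-TW01 cells (Homo sapiens) for inhibition, read by MTT assay, with a stated time of 72 h (on this read-out lower numbers stand for stronger inhibition of growth and higher numbers for weaker inhibition of growth), compound 2 gives the higher of the two numbers; the gap to compound 1 lies beyond the scatter. Compound 3 `O=Cc1c(-c2ccccc2)nn(-c2ccccc2)c1/N=C/N1CCCCC1` differs from compound 2 by piperidin-1-yl in place of diethylamino on a carbon with a double bond to nitrogen. Going by the values given here, no step between measured compounds covers this change, and the entering group is a close relative of the leaving one, so no step beyond the scatter is expected in this assay. The estimated step is a 1.2-fold lower number from compound 2 to compound 3 (0.09 log units; within the scatter). Compound 3 is accordingly expected to give about 25000 nM in this assay, within a range of 8000 nM to 80000 nM.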

Compound 3, concentration for 50% growth inhibition: 24400 nM
The estimate for compound 3 lay 1.0-fold (0.01 log units) above the measured number, and the stated range covers the measured number.
By their numbers in this assay, from the lowest: compound 1; then compounds 3 and 2 (each within the scatter of the next).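

In this assay, going by these compounds alone, the change from diethylamino to piperidin-1-yl on the carbon with a double bond to nitrogen gives a 1.3-fold lower number from compound 2 to compound 3 (0.10 log units; within the scatter) and is the first one-place comparison. At this place, an open diethylamino group and a six-membered piperidin-1-yl ring therefore read alike within the scatter. No measured evidence bears on this result.

Going by these compounds, whether a morpholin-4-yl or pyrrolidin-1-yl group would read the same here remains open. On these data alone, the separate contribution of the chlorine in compound 1 also remains open, as compound 1 differs from compound 2 and compound 3 in more than one place.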